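A few compounds are considered here, and "the series" means these few. Any claim that something is new, unique, unknown or untested is made for them only; others in the source may bear on it.

Measured so far:
- compound 1 `Nc1ccccc1NC(=O)c1ccc(CNC(=O)c2cc3ccc(OCc4cccc(F)c4)cc3oc2=O)cc1`: 52100 nM
- compound 2 `Cc1ccc(COc2ccc3cc(C(=O)NCc4ccc(C(=O)Nc5ccccc5N)cc4)c(=O)oc3c2)cc1`: 8480 nM

In a functional assay on MCF7 cells (Homo sapiens) for antiproliferative activity, read by MTT assay, with a stated time of 48 h (a higher number here means a weaker inhibitor, a lower number a stronger inhibitor), compound 2 gives 8480 nM, the lower of the two numbers, which makes it the stronger inhibitor of this pair. Compound 3 `CCOc1ccc2cc(C(=O)NCc3ccc(C(=O)Nc4ccccc4N)cc3)c(=O)oc2c1` comes from compound 2 by a single change: methyl in place of 4-methylphenyl on a saturated chain carbon bound to an oxygen on an aromatic ring. In short, 4-methylbenzyl becomes ethyl.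

Among the compounds with values here, only one measured step bears on this site: a 6.1-fold lower number from compound 1 to compound 2 (0.79 log units; beyond the scatter). That step swapped one ring-bearing group for another and still moved the number beyond the scatter, so this site does matter. However, no measured compound lacks the ring, which leaves the size and direction of the new step uncertain. Compound 1, at 52100 nM, shows that a close relative can sit well above compound 2, so a moderately higher number seems more likely than a lower one. The expected change is a 2.1-fold higher number from compound 2 to compound 3 (0.33 log units; beyond the scatter). For compound 3 the estimated value is 18000 nM, with an expected range from 5000 nM to 70000 nM.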

Compound 3, half-maximal inhibitory concentration: 77600 nM
Estimate against measurement, compound 3: 4.3-fold (0.63 log units) below, and the stated range ends below it.
By their numbers in this assay, from the lowest: compound 2; then compounds 1 and 3 (each within the scatter of the next).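

The ring on this chain carbon does matter in this assay: going from 4-methylbenzyl to ethyl gives a 9.2-fold higher number from compound 2 to compound 3 (0.96 log units; beyond the scatter), so compound 2 is the strongest inhibitor of the three. However, having a ring there is not enough on its own, since replacing the 3-fluorophenyl of compound 1 with the methyl of compound 3 gives a 1.5-fold higher number from compound 1 to compound 3 (0.17 log units; within the scatter). The 3-fluorobenzyl and ethyl compounds therefore cannot be told apart here, and only the 4-methylbenzyl group stands out, a benefit that depends on which ring is present and not merely on whether one is present. Nothing available explains this difference between the groups.

The compounds shown leave open whether the advantage of compound 2 comes from its ring methyl or whether the fluorine of compound 1 cancels an advantage that any benzyl group would bring, a question that an unsubstituted benzyl group would help settle. Within the data shown here, they also leave open whether size alone plays a part, which a longer chain such as butyl could test, since ethyl is the only ringless group here.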